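A few compounds are considered here, and "the series" means these few. Any claim that something is new, unique, unknown or untested is made for them only; others in the source may bear on it.

Among the compounds with values here, compound 2 `CC1=C(C(=O)OCCCO[N+](=O)[O-])C(c2cccc3nonc23)C([N+](=O)[O-])=C(C)C1` gives the highest of the two numbers measured so far in a functional assay (cardiac atrium) for agonist activity, with Cavia porcellus as the target (a lower number here means that less compound is needed, a higher number that more compound is needed for the effect), at 52300 nM. Within the data shown here, its nearest neighbour, compound 1 `CC1=C(C(=O)OCC(C)O[N+](=O)[O-])C(c2cccc3nonc23)C([N+](=O)[O-])=C(C)C1`, gives 972 nM in this assay, and the single measured step, a 54-fold higher number from compound 1 to compound 2 (1.73 log units; beyond the scatter), came from moving the branch on the chain that hangs from the ester oxygen. Compound 3 `CC1=C(C(=O)OC(C)C)C(c2cccc3nonc23)C([N+](=O)[O-])=C(C)C1` differs from compound 2 by isopropyl in place of 3-(nitrooxy)propyl on an oxygen next to a carbonyl group. Among the measured compounds shown here, that change again places a branch on the carbon bound to the ester oxygen, as in compound 1, so the step of a 35-fold lower number from compound 2 to compound 3 (1.54 log units; beyond the scatter) is expected to move the number down, although the loss of the nitrooxy group has no measured precedent. Compound 3 is therefore expected to give about 1500 nM, within 200 nM to 12000 nM.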

Compound 3, half-maximal effective concentration: 9400 nM
Compound 3: the middle estimate sits 6.3-fold (0.80 log units) below what was measured; low and high end bracket the measured number.
By their numbers in this assay, from the lowest: compound 1; then compound 3; then compound 2.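

In this assay, an ester with no nitrooxy group at all still sits below the straight-chain 3-(nitrooxy)propyl ester, with a 5.6-fold lower number from compound 2 to compound 3 (0.75 log units; beyond the scatter). It does not reach the branched nitrooxy ester, however, with a 9.7-fold higher number from compound 1 to compound 3 (0.99 log units; beyond the scatter), so at this oxygen, carrying a nitrooxy group can go with either a higher or a lower number, depending on the chain that holds it. No available evidence accounts for this. Open, as far as these compounds go, is what a plain propyl or a longer chain would give, which would help separate the contribution of the branch from that of the nitrooxy group.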